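The source may hold more compounds than are shown below. What is called first, only, known or untested is meant among the compounds shown, and "the series" means these compounds.

Measured in a functional assay on UACC-62 cells (Homo sapiens); on this read-out higher numbers stand for weaker inhibition of growth and lower numbers for stronger inhibition of growth:
- compound 1 `O=S(=O)(/C=C/c1ccc(C(F)(F)F)cc1F)Cc1ccc(Nc2ncnc3ccccc23)cc1`: 100000 nM
- compound 2 `O=S(=O)(/C=C/c1ccc(C(F)(F)F)cc1F)Cc1ccc(Nc2ncnc3ccc(Br)cc23)cc1`: 22000 nM
- compound 3 `O=S(=O)(/C=C/c1ccc(Cl)cc1Cl)Cc1ccc(Nc2ncnc3cc(Cl)ccc23)cc1`: 32000 nM

Compound 3, at 32000 nM, cannot be told apart from compound 2 within the scatter. Its number is lower than that of compound 1, and that gap lies beyond the scatter.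

Compound 4 `O=S(=O)(/C=C/c1ccc(C(F)(F)F)cc1F)Cc1ccc(Nc2ncnc3cc(Cl)ccc23)cc1` keeps the core of compound 3 and changes only the aryl group on the double-bonded chain: 2-fluoro-4-(trifluoromethyl)phenyl in place of 2,4-dichlorophenyl on a double-bonded chain carbon bound to a double-bonded chain carbon.

Within the data shown here, no measured pair isolates this swap. Among the measured compounds shown here, the one measured step, a 4.5-fold lower number from compound 1 to compound 2 (0.66 log units; beyond the scatter), is modest and lies beyond the scatter, but it is a bromo in place of hydrogen on the core and leaves the aryl group untouched. It therefore says little about the size of the swap. The indirect evidence comes from compound 2, at 22000 nM, which already carries 2-fluoro-4-(trifluoromethyl)phenyl together with a halogen on the core. Its value sits within the scatter of the compound bearing 2,4-dichlorophenyl, so the two aryl groups give no sign of separating in this assay, though the cores of that pair also differ.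

The expected result is a 1.1-fold lower number from compound 3 to compound 4 (0.03 log units; within the scatter), with no move beyond the scatter. For compound 4 the estimated value is 30000 nM, with an expected range of 14000 nM to 70000 nM.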

Compound 4, concentration for 50% growth inhibition: > 100000 nM
Compound 4: only a limit was reported; the forecaster's own chance of this, stated with the estimate: 5%; at least 3.3-fold (0.52 log units) between middle value and limit.
By their numbers in this assay, from the lowest: compounds 2 and 3 (each within the scatter of the next); then compound 1.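

Compound 4 stands in this assay only as a limit, > 100000 nM: the limit of > 100000 nM in this assay, at which 1 of the 4 values shown sits.

The aryl group on the double-bonded chain now has its first direct pair, and the swap to 2-fluoro-4-(trifluoromethyl)phenyl from 2,4-dichlorophenyl on the core of compound 3 is not neutral: an at least 3.1-fold higher number from compound 3 to compound 4 (0.49 log units; beyond the scatter). With that aryl group held fixed, the core also matters, as an at least 4.5-fold higher number from compound 2 to compound 4 (0.65 log units; beyond the scatter) shows, so 2-fluoro-4-(trifluoromethyl)phenyl does not set the read-out alone, and the effect of the swap can be stated for this one core only.

From the compounds shown here alone, one step cannot be read for size, a number no lower from compound 1 to compound 4 (the limit leaves the size open), and the swap remains untested as a matched pair on the core of compound 2 or compound 1. Also open, going by these compounds, is how an amine or a carboxylic acid on the aryl ring, in place of these halogen-bearing substituents, would compare with 2,4-dichlorophenyl on the core of compound 3.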